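The source may hold more compounds than are shown below. What is called first, only, known or untested is meant among the compounds shown, and "the series" means these compounds.

In a functional assay on Jurkat cells (Homo sapiens) for cytotoxicity, with a stated time of 48 h (on this read-out lower numbers stand for stronger inhibition and higher numbers for weaker inhibition), compound 1 `CCOC(=O)CC1C(C(=O)OCC)=C(N)Oc2ccccc21`, the shared core without any added ring, gives 91400 nM. Compound 2 `CCOC(=O)CC1C(C(=O)OCC)=C(N)Oc2ccc(-c3cc(O)cc(OC)c3)cc21` carries a 3-hydroxy-5-methoxyphenyl on an aromatic carbon and gives 4200 nM, while compound 3 `CCOC(=O)CC1C(C(=O)OCC)=C(N)Oc2ccc(-c3cc(O)cc(O)c3)cc21` carries a 3,5-dihydroxyphenyl there and gives 18300 nM. Compound 3 therefore holds the second highest of the three numbers, with compound 1 higher and compound 2 lower.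

The next change leads to compound 4 `CCOC(=O)CC1C(C(=O)OCC)=C(N)Oc2ccc(-c3ccc4ccccc4c3)cc21`, where naphthalen-2-yl takes the place of 3,5-dihydroxyphenyl on that aromatic carbon: naphthalen-2-yl in place of 3,5-dihydroxyphenyl on an aromatic carbon. Two measured steps show that adding a ring at this carbon lowers the number: a 22-fold lower number from compound 1 to compound 2 (1.34 log units; beyond the scatter) and a 5.0-fold lower number from compound 1 to compound 3 (0.70 log units; beyond the scatter). A third step, a 4.4-fold higher number from compound 2 to compound 3 (0.64 log units; beyond the scatter), shows the number rising where hydrogen replaces methyl on an oxygen on an aromatic ring. Within the data shown here, compound 4 has no hydroxy groups on its added ring, so this third step hints at a lower number, but no measured compound carries naphthalen-2-yl, and the guidance is indirect. In this assay, the expected step is modest and goes towards a lower number: a 2.8-fold lower number from compound 3 to compound 4 (0.45 log units; beyond the scatter). For compound 4 the estimate is 6500 nM, with an expected range from 2500 nM to 17000 nM.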

Compound 4, half-maximal inhibitory concentration: 18700 nM
Compound 4: the middle estimate sits 2.9-fold (0.46 log units) below what was measured; the measured number lies above the stated range.
By their numbers in this assay, from the lowest: compound 2; then compounds 3 and 4 (each within the scatter of the next); then compound 1.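

In this assay, the step of a 1.0-fold higher number from compound 3 to compound 4 (0.01 log units; within the scatter) shows that naphthalen-2-yl, with 0 hydrogen-bond donors, and 3,5-dihydroxyphenyl, with 2, cannot be told apart at this aromatic carbon, so the absence of hydroxy groups alone did not bring the number down. The step of a 4.5-fold higher number from compound 2 to compound 4 (0.65 log units; beyond the scatter) leaves compound 2 with the lowest number of the four, and the rise seen when its methyl is replaced by hydrogen therefore does not extend to this all-carbon pair of rings. The step of a 4.9-fold lower number from compound 1 to compound 4 (0.69 log units; beyond the scatter) shows that all three compounds with an added ring at this carbon now have lower numbers than compound 1, even though the added rings differ considerably.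

The compounds shown leave open whether the edge of compound 2 depends on having both a hydroxy and a methoxy group on the added ring, and how an amine or a carboxylic acid on that ring would compare. Nothing available here explains why these added groups differ or why two such different ones match.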